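Variation of the group on the aromatic oxygen: compound 4

The source may hold more compounds than are shown below. What is called first, only, known or untested is meant among the compounds shown, and "the series" means these compounds.

Values in a functional assay on HEK293 cells for agonist activity at Free fatty acid receptor 1 (Homo sapiens), read by fluorescence and calcium flux, with a stated time of 10 min; on this read-out higher numbers stand for an effect only at larger amounts of compound and lower numbers for an effect already at smaller amounts:
compound 1, `CC#C[C@@H](CC(=O)O)c1ccc(OC[C@H]2COc3ccc(C)cc3O2)cc1`: 120 nM
compound 2, `CC#C[C@@H](CC(=O)O)c1ccc(OC[C@H]2COc3ccc(OC)cc3O2)cc1`: 130 nM
compound 3, `CC#C[C@@H](CC(=O)O)c1ccc(OC[C@H]2COc3ccc(OC(C)C)cc3O2)cc1`: 280 nM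

Compound 3 stands highest of the three numbers in this assay. The two steps leading to it are both beyond the scatter: a 2.3-fold higher number from compound 1 to compound 3 (0.37 log units; beyond the scatter) and a 2.2-fold higher number from compound 2 to compound 3 (0.33 log units; beyond the scatter). The step between the other two, a 1.1-fold higher number from compound 1 to compound 2 (0.03 log units; within the scatter), lies within the scatter, so compound 1 and compound 2 are not separated.

Compound 4, `CC#C[C@@H](CC(=O)O)c1ccc(OC[C@H]2COc3ccc(OC(F)(F)F)cc3O2)cc1`, differs from compound 3 by trifluoromethyl in place of isopropyl on an oxygen on an aromatic ring. Going by the values given here, no measured step covers a trifluoromethyl on this oxygen. Among the compounds with values here, the steps that bear on the change are those at the same place: a 2.2-fold higher number from compound 2 to compound 3 (0.33 log units; beyond the scatter), where the group on this oxygen was changed, and a 2.3-fold higher number from compound 1 to compound 3 (0.37 log units; beyond the scatter), both modest. A step of at most that size is therefore expected in this assay, with the direction undetermined; a return toward the number of compound 2 is about as plausible as no step beyond the scatter.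

For compound 4 the expected step is a 1.4-fold lower number from compound 3 to compound 4 (0.15 log units; within the scatter). Compound 4 is estimated at 200 nM in this assay, within 90 nM to 450 nM.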

Compound 4, half-maximal effective concentration: 700 nM
For compound 4 the middle estimate is 3.5-fold (0.54 log units) below the measured one; measured number above the stated range.
By their numbers in this assay, from the lowest: compounds 1 and 2 (each within the scatter of the next); then compound 3; then compound 4.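

Going by these compounds alone, on the oxygen on the aromatic ring, the substituent matters more in this assay than the earlier compounds showed: trifluoromethyl in place of isopropyl gives (a 2.5-fold higher number from compound 3 to compound 4 (0.40 log units; beyond the scatter)), although neither group carries a ring, a hydrogen-bond donor or acceptor, or a net charge. Against the smaller groups, the separation widens (a 5.4-fold higher number from compound 2 to compound 4 (0.73 log units; beyond the scatter)) for trifluoromethyl in place of methyl on this oxygen, and (a 5.8-fold higher number from compound 1 to compound 4 (0.77 log units; beyond the scatter)) for trifluoromethoxy in place of methyl on the aromatic carbon. Compound 4 therefore has the highest number of the four, beyond the scatter of each of the others, so the two oxygen-linked alkyl groups did not mark the upper end of the range at this position.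

No available data explain the shift. On these data alone, how a difluoromethyl or an ethyl on this oxygen, or a chlorine directly on the aromatic carbon, would stand in this assay remains open.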